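The source may hold more compounds than are shown below. What is called first, only, known or untested is meant among the compounds shown, and "the series" means these compounds.

Working notes on the series in a functional assay on the whole organism for inhibition, with Mus musculus as the target, at a dose of 1 mg/kg by the oral route; on this read-out higher numbers stand for more inhibition at the one dose given (going by the name of the read-out) and lower numbers for less inhibition.

Of the compounds shown here, two have been measured. Compound 1 `CCN(C(=O)c1c(O)c2c(C)cccc2n(C)c1=O)c1ccccc1` gives 65% in this assay, the highest of the two numbers in hand. Its nearest neighbour is compound 2 `C=CCN(C(=O)c1c(O)c2c(Cl)cccc2n(C)c1=O)c1ccccc1`, which in this assay gives 59%; the gap between the two readings lies within the usual scatter, so the two values show no order between compound 1 and compound 2. Within the data shown here, compound 2 differs from compound 1 in two places at once, so no single step joins them.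

Compound 3 `CCN(C(=O)c1c(O)c2c(Br)cccc2n(C)c1=O)c1ccccc1` has not yet been measured. Its relation to compound 1 is bromo in place of methyl on an aromatic carbon. Compound 2 also carries a halogen, a chloro, in place of the methyl of compound 1, together with a second change, and compound 2 gives 59%, a reading that stays near that of compound 1. On that basis the step of a number 5 percentage points lower from compound 1 to compound 3 (within the scatter) is expected to be small, if anything slightly downward, and not beyond the scatter. Compound 3 is therefore estimated at 60%, with a range from 45% to 75%.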

Compound 3, a percentage reported as inhibition, in the whole organism at one dose (the size of the read-out at that dose, not a potency): 95%
For compound 3 the middle estimate is 35 percentage points below the measured one; the whole stated range lies below it.
By their numbers in this assay, from the lowest: compounds 2 and 1 (each within the scatter of the next); then compound 3.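

In this assay, among these compounds, bromo in place of methyl on an aromatic carbon, ortho to a fused ring and meta to a fused ring, gives a number 30 percentage points higher from compound 1 to compound 3 (beyond the scatter) and so provides the first single-place step. This position therefore responds to the exchange of one group for another, something the two earlier compounds could not show, since they differ in two places at once. Methyl and bromo have the same counts of heavy atoms, hydrogen-bond donors and acceptors, and neither carries a net charge, so those counts do not separate them, and no measurement at hand accounts for the step.

Chloro appears only in compound 2, together with a second change, so its effect at this position cannot be read on its own, and the series does not show whether the result is particular to bromo or extends to other halogens such as fluoro or iodo. Also open, on these data alone, are how a methoxy, a nitrile or an amine would read at this position, and whether the step persists when the ethyl chain gives way to a longer chain.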